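From 4-methylphenyl to 4-ethylphenyl: a small step

This account rests on a few compounds, and the source may have more. Where it says the series, first, only, none or still open, it means among the compounds named here.

Compound 1 `CC(C)n1ncc2c(C(=O)NCc3cn(-c4ccc(I)cc4)nn3)cccc21`: in a functional assay on PC-3 cells (Homo sapiens) for inhibition, read by MTT assay, with a stated time of 72 h (a lower number here means a stronger inhibitor, a higher number a weaker inhibitor), compound 1 gives > 40000 nM, which is a limit of the assay and not a number.
Compound 2 `CC(C)n1ncc2c(C(=O)NCc3cn(-c4ccc([N+](=O)[O-])cc4)nn3)cccc21`: in this assay compound 2 gives > 40000 nM, again a limit rather than a number.
Compound 3 `Cc1ccc(-n2cc(CNC(=O)c3cccc4c3cnn4C(C)C)nn2)cc1`: in this assay compound 3 gives 39000 nM.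

Compound 3 is thus the only one of the three with an actual number, and that number sits close to the limit at which the other two values stop (the limit of > 40000 nM in this assay, at which 2 of the 3 values shown sit). Swapping the groups on the aromatic carbon gave no readable change: an at least 1.0-fold lower number from compound 1 to compound 3 (0.01 log units; that floor lies within the scatter) and an at least 1.0-fold lower number from compound 2 to compound 3 (0.01 log units; that floor lies within the scatter), both within the scatter, and a step that the two limits leave unreadable from compound 1 to compound 2.

Within the data shown here, compound 4 `CCc1ccc(-n2cc(CNC(=O)c3cccc4c3cnn4C(C)C)nn2)cc1` carries the one change (methyl in place of hydrogen on a saturated chain carbon bound to an aromatic carbon). Among the measured compounds shown here, no measured step touches this kind of change; the nearby steps show only that varying this part of the molecule has left the numbers flat near the limit. In this assay compound 4 is therefore expected to give 40000 nM, within 18000 nM to 90000 nM, with a fair chance that only a limit is reported. The expected step is a 1.0-fold higher number from compound 3 to compound 4 (0.01 log units; within the scatter), none beyond the scatter.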

Compound 4, half-maximal inhibitory concentration: 26600 nM
For compound 4 the middle estimate is 1.5-fold (0.18 log units) above the measured one; low and high end bracket the measured number.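

Methyl to ethyl is the first change at this place, a saturated chain carbon bound to an aromatic carbon, that joins two actual numbers: in this assay the step is a 1.5-fold lower number from compound 3 to compound 4 (0.17 log units; within the scatter) and so shows no readable effect of this change. The floors against the other two groups are an at least 1.5-fold lower number from compound 2 to compound 4 (0.17 log units; that floor lies within the scatter) and an at least 1.5-fold lower number from compound 1 to compound 4 (0.17 log units; that floor lies within the scatter) and do not separate ethyl from nitro or iodo. Compound 1 and compound 2 stay limits and not numbers, so the series still sits against one edge of the assay: the limit of > 40000 nM in this assay, at which 2 of the 4 values shown sit.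

As far as these compounds go, whether a longer chain such as butyl, or an amine or a carboxylic acid in place of the ethyl, would move the number beyond the scatter stays open. So does whether any change on this aromatic ring can bring a number far from that limit.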